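The compounds below may be only part of what the source reports. "The series", "measured", "known", "first", "only" and "open" are said of these compounds alone.

In an ADME assay on microsomes from liver (Mus musculus) for metabolic stability, using NADPH, with a stated time of 10 min (a higher number here means that more of the compound is left, a lower number that less of the compound is left), compound 3 `c1cnc2c(c1)CN[C@@H](CN(CCCCNC1CCOCC1)[C@H]1CCCc3cccnc31)C2` gives 35% and compound 1 `NC/C=C/CN(C[C@H]1Cc2ncccc2CN1)[C@H]1CCCc2cccnc21` gives 37%, two values within the scatter of each other, while compound 2 `CN(C)CCCCN(C[C@H]1Cc2ncccc2CN1)[C@H]1CCCc2cccnc21` stands clearly higher at 55%. Compound 4 `CN(CCCCN(C[C@H]1Cc2ncccc2CN1)[C@H]1CCCc2cccnc21)C1CCOCC1` differs from compound 3 by a single change, methyl in place of hydrogen on an amine nitrogen. The nearest evidence is a number 20 percentage points lower from compound 2 to compound 3 (beyond the scatter), where (oxan-4-yl)amino took the place of dimethylamino. Compound 4 keeps the oxan-4-yl group of compound 3 and gains a methyl as found in compound 2, so it may recover only part of that gap. The expected step is small and upward: a number 7 percentage points higher from compound 3 to compound 4 (within the scatter). Compound 4 is estimated at 42%, with an expected range from 27% to 58%.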

Compound 4, percent of the compound remaining: 51%
Compound 4: the middle estimate sits 9 percentage points below what was measured; measured number inside the range.
By their numbers in this assay, from the lowest: compounds 3 and 1 (each within the scatter of the next); then compounds 4 and 2 (each within the scatter of the next).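

On the amine nitrogen that carries oxan-4-yl, methyl in place of hydrogen makes a real difference (a number 16 percentage points higher from compound 3 to compound 4 (beyond the scatter)). Once that nitrogen has no hydrogen left, swapping one of its groups matters little: oxan-4-yl in place of methyl gives only a small shift (a number 4 percentage points lower from compound 2 to compound 4 (within the scatter)), and the full side chain of compound 4 still stands apart from the shorter one of compound 1 (a number 14 percentage points higher from compound 1 to compound 4 (beyond the scatter)). No measurement shown explains the rise. From the compounds shown here alone, whether ethyl or acetyl on that nitrogen would act as methyl does remains open.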